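Indole to Amide Exchange on the Piperidine Nitrogen

The compounds below may be only part of what the source reports. "The series", "measured", "known", "first", "only" and "open" are said of these compounds alone.

Compound 3 `COc1ccc2nccc(C3CN(C4CCN(Cc5ccc(C#N)cc5)CC4)C(=O)O3)c2c1` gives 12600 nM in an in vitro functional assay on RBL cells for antagonist activity at C-C chemokine receptor type 8 (Homo sapiens), read by FLIPR and calcium flux (a higher number here means a weaker inhibitor, a lower number a stronger inhibitor), and stands highest of the two numbers reported. Its nearest neighbour is compound 1 `COc1ccc2nccc(C3CN(C4CCN(Cc5cc6ccccc6[nH]5)CC4)C(=O)O3)c2c1`, which gives 25.1 nM, a gap of a 500-fold higher number from compound 1 to compound 3 (2.70 log units; beyond the scatter). Compound 2 `COc1ccc2nccc(C3CN(C4CCN(Cc5c[nH]c6ccccc56)CC4)C(=O)O3)c2c1` is reported only as a limit of the assay, < 50200 nM. Compound 4 `COc1ccc2nccc(C3CN(C4CCN(C(=O)c5ccc(Cl)c(Cl)c5)CC4)C(=O)O3)c2c1` differs from compound 3 by (3,4-dichlorophenyl)carbonyl in place of 4-cyanobenzyl on an amine nitrogen in a ring. Among the compounds with values here, no measured step exchanges the benzylic chain for a carbonyl; only the step from compound 1 to compound 3 touches this position, and it shows that the group there can shift the read-out by a 500-fold higher number from compound 1 to compound 3 (2.70 log units; beyond the scatter). The direction for compound 4 cannot be read from the data, so compound 4 is expected to give about 10000 nM, within 800 nM to 50000 nM, a step of a 1.3-fold lower number from compound 3 to compound 4 (0.10 log units; within the scatter) that is estimated only loosely.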

Compound 4, half-maximal inhibitory concentration: 6310 nM
Compound 4: the middle estimate sits 1.6-fold (0.20 log units) above what was measured; the range from low to high includes it.
By their numbers in this assay, from the lowest: compound 1; then compounds 4 and 3 (each within the scatter of the next).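

In this assay, within the data shown here, the amine nitrogen in a ring now carries a carbonyl-linked group for the first time, and the exchange of 4-cyanobenzyl for (3,4-dichlorophenyl)carbonyl gives a 2.0-fold lower number from compound 3 to compound 4 (0.30 log units; within the scatter). The (1H-indol-2-yl)methyl group stays apart from this new group as well, with a 250-fold higher number from compound 1 to compound 4 (2.40 log units; beyond the scatter). Compound 2 is reported only as a limit, and its step to compound 4 cannot be read: the limit of < 50200 nM in this assay, at which 1 of the 4 values shown sits.

From the compounds shown here alone, both the linker and the ring substituents change together in compound 4, so their separate contributions stay open. Going by these compounds, it also remains open how a (1H-indol-2-yl)carbonyl or a 3,4-dichlorobenzyl group would read at this nitrogen.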